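The source may report more compounds than this note shows. Statements on the series, on what has been measured and on what is new or still open speak of the compounds shown alone.

Compound 1 `Cn1ccc2c(Oc3ccc(NC(=O)c4cc5cccnc5n(-c5ccccc5)c4=O)cc3)ccnc21`: 850 nM
Compound 2 `Cn1ccc2c(Oc3ccc(NC(=O)c4cc5cccnc5n(-c5ccc(F)cc5)c4=O)cc3)ccnc21`: 210 nM
Compound 3 `Cn1ccc2c(Oc3ccc(NC(=O)c4cc5cccnc5n(-c5ccc(Br)cc5)c4=O)cc3)ccnc21`: 680 nM

In a functional assay on A549 cells (Homo sapiens) for antiproliferative activity, read by MTT assay, with a stated time of 72 h (a lower number here means a stronger inhibitor, a higher number a weaker inhibitor), compound 3 gives 680 nM. Its number sits close to that of compound 1, since a 1.3-fold lower number from compound 1 to compound 3 (0.10 log units; within the scatter) lies within the scatter, while a 3.2-fold higher number from compound 2 to compound 3 (0.51 log units; beyond the scatter) is a modest step beyond it. Compound 4 `COc1ccc(-n2c(=O)c(C(=O)Nc3ccc(Oc4ccnc5c4ccn5C)cc3)cc3cccnc32)cc1` differs from compound 3 by methoxy in place of bromo on an aromatic carbon. Among the compounds with values here, no measured step exchanges bromo for methoxy; the steps that bear on it are a 1.3-fold lower number from compound 1 to compound 3 (0.10 log units; within the scatter) and a 3.2-fold higher number from compound 2 to compound 3 (0.51 log units; beyond the scatter), which show only that the bromo compound sits near the unsubstituted one. A small change of uncertain direction is therefore expected for compound 4, a 1.2-fold lower number from compound 3 to compound 4 (0.09 log units; within the scatter), quite possibly not beyond the scatter. The estimate for compound 4 is 550 nM, ranging from 200 nM to 1500 nM.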

Compound 4, half-maximal inhibitory concentration: 3460 nM
Estimate against measurement, compound 4: 6.3-fold (0.80 log units) below; measured number outside the range, above it.
By their numbers in this assay, from the lowest: compound 2; then compounds 3 and 1 (each within the scatter of the next); then compound 4.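

In this assay this position proves sensitive to the group placed on it: methoxy weakens activity against hydrogen (a 4.1-fold higher number from compound 1 to compound 4 (0.61 log units; beyond the scatter)), against bromo (a 5.1-fold higher number from compound 3 to compound 4 (0.71 log units; beyond the scatter)) and, most of all, against fluoro (a 16-fold higher number from compound 2 to compound 4 (1.22 log units; beyond the scatter)). The closeness of the bromo and unsubstituted compounds therefore did not mean that any group is tolerated here. No measurement at hand explains this loss. Going by these compounds, whether an amine or an ethoxy group in the same place would match methoxy remains open. Where chloro would stand also remains open.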